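The source may report more compounds than this note shows. Statements on the series, on what has been measured and on what is new or still open speak of the compounds shown alone.

Measured compounds:
compound 1 `O=C(CCCCC1CCSS1)NCc1cn(CCCOc2ccc3ccc(=O)oc3c2)nn1`: 40%
compound 2 `O=C(CCCCC1CCSS1)NCc1cn(CCCOc2ccc3cc(-c4ccccc4)c(=O)oc3c2)nn1`: 29.1%

Both were tested in a functional assay on PC-12 cells (Rattus norvegicus) for cytotoxicity, read by MTT assay, with stated times of 3 h and 2 h, tested at 10 uM; on this read-out higher numbers stand for a stronger effect at the one concentration tested and lower numbers for a weaker effect. In this assay compound 1 gives 40%, and compound 2 gives 29.1%. Among the compounds with values here, compound 2 thus holds the lower of the two numbers, and the only measured step, a number 10.9 percentage points lower from compound 1 to compound 2 (beyond the scatter), is the one that separates it from compound 1.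

Compound 3 `O=C(CCCCC1CCSS1)NCc1cn(CCCOc2ccc3cc(-c4ccc(Cl)c(Cl)c4)c(=O)oc3c2)nn1` has not yet been measured. It differs from compound 2 by 3,4-dichlorophenyl in place of phenyl on an aromatic carbon. Within the data shown here, no measured step involves adding chlorine to a ring, so the one step seen so far, which concerns phenyl in place of hydrogen rather than a change on the phenyl itself, gives no direct guide to the direction or size of this change. With nothing to point either way, the expected step of a number 0.9 percentage points higher from compound 2 to compound 3 (within the scatter) is small and likely within the usual scatter. Compound 3 is therefore estimated at 30% in this assay, with a range from 15% to 45%.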

Compound 3, a percentage reported as activity, at one concentration (the size of the read-out at that concentration, not a potency): 49.6%
The estimate for compound 3 lay 19.6 percentage points below the measured number; measured number outside the range, above it.
By their numbers in this assay, from the lowest: compound 2; then compounds 1 and 3 (each within the scatter of the next).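

In this assay, the aromatic carbon that carries the phenyl in compound 2 turns out to be sensitive to what sits on that phenyl and not only to whether a phenyl is there: 3,4-dichlorophenyl in place of phenyl gives a number 20.5 percentage points higher from compound 2 to compound 3 (beyond the scatter). This also shows that an aromatic ring at this place does not by itself bring the number down, as the earlier step from hydrogen to phenyl alone might have suggested, since 3,4-dichlorophenyl in place of hydrogen gives a number 9.6 percentage points higher from compound 1 to compound 3 (within the scatter), which leaves compound 3 and compound 1 not separable on this read-out. No measurement here accounts for why the two chlorine atoms change the result in this way.

The compounds shown leave open whether both chlorine atoms are needed for this step or whether a single chlorine on the phenyl would give the same number. They also leave open whether other groups on that phenyl, such as a methoxy group or an amine, would move the number in the same direction as chlorine.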